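Bromine Step Repeated on a Larger Scaffold

The compounds below may be only part of what the source reports. "The series", "measured", "known", "first", "only" and "open" are said of these compounds alone.

Compound 1 `Cc1cc(O)c(C(=O)/C=C/c2ccccc2)c(-c2ccccc2)c1C(=O)/C=C/c1ccccc1` and compound 2 `Cc1cc(O)c(C(=O)/C=C/c2ccccc2)c(-c2ccc(Br)cc2)c1C(=O)/C=C/c1ccccc1` share one core and differ in a single place: bromo in place of hydrogen on an aromatic carbon. In a functional assay on MCF7 cells (Homo sapiens) for cytotoxicity, read by MTT assay, with a stated time of 24 h (on this read-out higher numbers stand for weaker inhibition and lower numbers for stronger inhibition), compound 1 gives 10000 nM, and compound 2 gives 10000 nM, so that no change at the digits printed from compound 1 to compound 2 (within the scatter). Compound 3 `Cc1cc(O)c(C(=O)/C=C/c2ccc(OCc3ccccc3)cc2)c(-c2ccccc2)c1C(=O)/C=C/c1ccc(OCc2ccccc2)cc1` is built on a related core; the difference between the two cores is not broken down here. In this assay compound 3 gives 10000 nM. Compound 4 `Cc1cc(O)c(C(=O)/C=C/c2ccc(OCc3ccccc3)cc2)c(-c2ccc(Br)cc2)c1C(=O)/C=C/c1ccc(OCc2ccccc2)cc1` is not yet measured and differs from compound 3 by bromo in place of hydrogen on an aromatic carbon, the same change seen from compound 1 to compound 2, occurring twice among these compounds. Because the earlier step of no change at the digits printed from compound 1 to compound 2 (within the scatter), a step of similar size is expected, no change at the digits printed from compound 3 to compound 4 (within the scatter). Compound 4 is therefore expected to give about 10000 nM in this assay, likely between 5000 nM and 20000 nM.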

Compound 4, half-maximal inhibitory concentration: 20000 nM
The estimate for compound 4 lay 2.0-fold (0.30 log units) below the measured number; the range from low to high includes it.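

In this assay, putting bromo in place of hydrogen gives a 2.0-fold higher number from compound 3 to compound 4 (0.30 log units; within the scatter), and the two appearances of this change agree: the same change on two cores in this assay, no change at the digits printed (within the scatter) from compound 1 to compound 2 and a 2.0-fold higher number (0.30 log units; within the scatter) from compound 3 to compound 4, 2.0-fold (0.30 log units) apart, within the scatter of two such steps. The change from phenyl to 4-bromophenyl therefore carries over between these two cores, in the sense that neither step moves the number beyond the usual scatter of the measurement. This does not show that bromo has any effect of its own on the cells, and two cores are too few to speak for the rest of the series.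

The compounds shown leave open whether a different group in the same place, such as an amine or a carboxylic acid, would move the number beyond the scatter. They also leave open what bromo would do elsewhere on that ring.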